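Swapping chloro for isopropyl on a biphenyl agonist

This account rests on a few compounds, and the source may have more. Where it says the series, first, only, none or still open, it means among the compounds named here.

Measured compounds:
Compound 1 `COc1cc(C)c(-c2cccc(COc3ccc(S(=O)(=O)CC(=O)O)cc3)c2)c(C)c1` gives 57.5 nM in a functional assay on CHO cells for agonist activity at Free fatty acid receptor 1 (Homo sapiens), read by FLIPR and calcium flux; on this read-out lower numbers stand for an effect already at smaller amounts and higher numbers for an effect only at larger amounts of compound.
Compound 2 `O=C(O)CS(=O)(=O)c1ccc(OCc2cccc(-c3ccccc3Cl)c2)cc1` gives 28.8 nM in this assay.

Among the compounds with values here, compound 2 shows the lower of the two numbers, but the only step that joins the two measured compounds, a 2.0-fold lower number from compound 1 to compound 2 (0.30 log units; within the scatter), does not go beyond the scatter of repeated measurements, so the two values cannot be told apart with confidence.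

Compound 3 `CC(C)c1ccccc1-c1cccc(COc2ccc(S(=O)(=O)CC(=O)O)cc2)c1` is the next compound to consider. Compared with compound 2 it differs by isopropyl in place of chloro on an aromatic carbon. Within the data shown here, there is only one measured step to lean on, a 2.0-fold lower number from compound 1 to compound 2 (0.30 log units; within the scatter), and it is small; it swaps the whole aromatic substituent pattern rather than a single group, so it speaks to the same region of the molecule only loosely. Nothing measured here points to a change beyond the scatter in this assay when chloro gives way to isopropyl.

The expected step is therefore a 1.2-fold higher number from compound 2 to compound 3 (0.08 log units; within the scatter), essentially none. The estimate for compound 3 is 35 nM, with a range from 12 nM to 100 nM.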

Compound 3, half-maximal effective concentration: 74.1 nM
Compound 3: middle estimate off by 2.1-fold (0.33 log units), on the low side; the range from low to high includes it.
By their numbers in this assay, from the lowest: compounds 2, 1 and 3 (each within the scatter of the next, the first and the last beyond it).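

In this assay the change from 2-chlorophenyl to 2-isopropylphenyl gives a 2.6-fold higher number from compound 2 to compound 3 (0.41 log units; beyond the scatter) and is the only step shown that clears the scatter, so the read-out does respond, modestly, to which group sits on this aromatic carbon. The other new comparison, a 1.3-fold higher number from compound 1 to compound 3 (0.11 log units; within the scatter), stays within the scatter, so 2-isopropylphenyl and 4-methoxy-2,6-dimethylphenyl cannot be told apart, and compound 2 stands clear of compound 3 alone, not of compound 1. Why chloro and isopropyl differ here cannot be said, as no supporting measurement bears on this result.

Within the data shown here, with only two single groups compared at this carbon, it remains open how methyl, methoxy or trifluoromethyl would behave there, and so whether any trend runs through this position at all. From the compounds shown here alone, it also remains open whether the gap between chloro and isopropyl would persist if another part of the molecule changed, for example if an amide took the place of the carboxylic acid.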